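The source may hold more compounds than are shown below. What is called first, only, known or untested is meant among the compounds shown, and "the series" means these compounds.

Compound 3 `COc1cc2ncnc(Nc3cccc(Cl)c3)c2cc1B1OC(C)(C)C(C)(C)O1` was tested in an assay on isolated protein for inhibition of vascular endothelial growth factor receptor 1 (Homo sapiens), read by ELISA, with a stated time of 20 min; a higher number here means a weaker inhibitor, a lower number a stronger inhibitor. In this assay compound 3 gives > 1000 nM, which is a limit of the assay rather than a number. Compound 1 `CC1(C)OB(c2ccc3ncnc(Nc4cccc(Cl)c4)c3c2)OC1(C)C` gives > 1000 nM, again a limit. Compound 2 `COc1cc2ncnc(Nc3ccc(F)c(Cl)c3)c2cc1B(O)O` gives > 1000 nM, also a limit. The change from compound 1 to compound 3 is therefore a step that the two limits leave unreadable from compound 1 to compound 3. Compound 4 `COc1cc2ncnc(Nc3ccc(F)c(Cl)c3)c2cc1B1OC(C)(C)C(C)(C)O1` differs from compound 3 by fluoro in place of hydrogen on an aromatic carbon. For the measured compounds named here, no measured step reads on this change, and every value shown sits at the limit of > 1000 nM in this assay, at which 3 of the 3 values shown sit, so no step beyond the scatter can be expected. The step from compound 3 to compound 4 is estimated at a step that the limit leaves unreadable from compound 3 to compound 4. Compound 4 is expected to give about 3000 nM, within 800 nM to 20000 nM, most likely reported once more as a limit.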

Compound 4, half-maximal inhibitory concentration: > 1000 nM
Compound 4 gave a limit, no number (the forecaster's own chance of this, stated with the estimate: 85%); the middle value lies beyond the limit too.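

Neither the step from compound 3 to compound 4 nor the one from compound 2 to compound 4 can be read, as the values are limits, not numbers: the limit of > 1000 nM in this assay, at which 4 of the 4 values shown sit.

Going by these compounds, whether the fluoro group or the swap of boron groups changes inhibition at all remains open.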